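One Changed Stereocentre, Starting From a Limit

The compounds below may be only part of what the source reports. "The series", "measured", "known", "first", "only" and "open" are said of these compounds alone.

In a functional assay on A549 cells (Homo sapiens) for cytotoxicity, read by MTT assay, with a stated time of 24 h (on this read-out higher numbers stand for weaker inhibition and lower numbers for stronger inhibition), compound 1 `CC(=O)O[C@@]1(C)CCC(=O)[C@H](C)CCC[C@]2(C)O[C@H]2C(=O)C(=C(C)C)CC1` gives > 50000 nM, which is a limit of the assay and not a number. Compound 2 `CC(C)=C1CC[C@]2(C)CC[C@]3(O[C@H](C[C@H]3C)C[C@]3(C)O[C@H]3C1=O)O2` gives > 50000 nM, which is also a limit. The data so far therefore consist of the limit of > 50000 nM in this assay, at which 2 of the 2 values shown sit.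

Compound 3 `CC(=O)O[C@@]1(C)CCC(=O)[C@@H](C)CCC[C@]2(C)O[C@H]2C(=O)C(=C(C)C)CC1` is very close to compound 1: the two compounds have the same atoms and bonds and differ only in configuration as drawn: 1 of 4 stereo elements differ; a stereocentre at a saturated ring carbon is drawn R in compound 1 and S in compound 3. For the measured compounds named here, no pair of measured compounds shows what a change of this kind does, so no step beyond the usual scatter is expected in this assay. This expectation rests only on compound 1, whose > 50000 nM is a limit. The expected step is a number no higher from compound 1 to compound 3 (the limit leaves the size open), with no clear direction. For compound 3, the estimated value is 50000 nM, with an expected range of 25000 nM to 100000 nM, and the assay may well report only a limit again.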

Compound 3, half-maximal inhibitory concentration: 31100 nM
Compound 3: the middle estimate sits 1.6-fold (0.21 log units) above what was measured, and the stated range covers the measured number.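

Redrawing this one saturated ring carbon from R to S gives a real number in this assay, where the earlier compounds gave none, and the change reads as an at least 1.6-fold lower number from compound 1 to compound 3 (0.20 log units; that floor lies within the scatter). Compound 1 gives > 50000 nM, which is a limit and not a number. The true gap may therefore be larger than this floor or may lie within the scatter, and the comparison isolates a single feature: the fact that compounds 1 and 3 differ only in the configuration as drawn

Going by these compounds, it remains open whether changing any of the other stereo elements would also shift the result, or whether a new group on the shared core, such as an amine or a carboxylic acid, would do so. Most of the data still offer no numbers to compare: the limit of > 50000 nM in this assay, at which 2 of the 3 values shown sit.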